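This account rests on a few compounds, and the source may have more. Where it says the series, first, only, none or still open, it means among the compounds named here.

Measured compounds:
Compound 1, `O=C(NCCNS(=O)(=O)c1sccc1-c1ccccc1Oc1ccc(O)c(O)c1)Nc1cc(Cl)cc(Cl)c1`: in a functional assay on HL-60 cells (Homo sapiens) for inhibition, read by CCK-8 assay, with a stated time of 48 h (a higher number here means a weaker inhibitor, a lower number a stronger inhibitor), compound 1 gives 6900 nM.
Compound 2, `Cc1ccc(-c2ccsc2S(=O)(=O)NCCNC(=O)Nc2cc(C(F)(F)F)cc(C(F)(F)F)c2)c(Oc2ccc(O)c(O)c2)c1`: in this assay compound 2 gives 3700 nM.
Compound 3, `Cc1ccc(-c2ccsc2S(=O)(=O)NCCNC(=O)Nc2cc(Cl)cc(Cl)c2)c(Oc2ccc(O)c(O)c2)c1`: in this assay compound 3 gives 3500 nM.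

Compounds 3 and 1 share one core and differ in a single place, (hydrogen in place of methyl on an aromatic carbon); that change gave a 2.0-fold higher number from compound 3 to compound 1 (0.29 log units; within the scatter). Compound 2 carries a different substituent on the urea-bound ring than compound 3, and the difference between the two cores is not broken down here; the two values of compound 2 and compound 3 lie within the scatter of each other.

Compound 4, `O=C(NCCNS(=O)(=O)c1sccc1-c1ccccc1Oc1ccc(O)c(O)c1)Nc1cc(C(F)(F)F)cc(C(F)(F)F)c1`, has not been measured in this assay. It differs from compound 2 by hydrogen in place of methyl on an aromatic carbon, which is the same change, at the same place, as that from compound 3 to compound 1. Because the measured step of a 2.0-fold higher number from compound 3 to compound 1 (0.29 log units; within the scatter) stayed within the scatter, the step from compound 2 to compound 4 is expected to be of the same size, a 1.9-fold higher number from compound 2 to compound 4 (0.28 log units; within the scatter). On that basis compound 4 is estimated at 7000 nM, with a likely range from 3500 nM to 14000 nM.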

Compound 4, half-maximal inhibitory concentration: 5700 nM
Beside the measured number, compound 4's estimate is 1.2-fold (0.09 log units) above it; low and high end bracket the measured number.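

In this assay, hydrogen in place of methyl on the aromatic carbon gave a 1.5-fold higher number from compound 2 to compound 4 (0.19 log units; within the scatter), and the step agrees with the one seen earlier on the other core: the same change on two cores in this assay, a 2.0-fold higher number (0.29 log units; within the scatter) from compound 3 to compound 1 and a 1.5-fold higher number (0.19 log units; within the scatter) from compound 2 to compound 4, 1.3-fold (0.11 log units) apart, within the scatter of two such steps. Within these two cores, which differ on the urea-bound ring, the swap therefore carries over with no difference that the data can resolve. Each step lies within the scatter, however, so the data do not show that the methyl matters at all in this assay, and a match across two cores says nothing about cores that differ elsewhere.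

The compounds shown leave open whether another group on that aromatic carbon, such as a methoxy group or an amine, would give a step beyond the scatter. They also leave open whether the same swap would hold on a core with a carboxylic acid in place of the 3,4-dihydroxyphenoxy group.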